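This account rests on a few compounds, and the source may have more. Where it says the series, first, only, none or still open, it means among the compounds named here.

Measured so far in a toxicity assay on MT4 cells (Homo sapiens) for cytotoxicity, read by MTT assay (a higher number here means that more compound is tolerated, a lower number that less compound is tolerated), for this series:

compound 1 `Cc1cc(-c2ccccc2Cl)cc(C)c1Oc1cc(N)nc(Nc2ccc(C#N)cc2)n1` gives 25100 nM
compound 2 `Cc1ccc(-c2cc(C)c(Oc3cc(N)nc(Nc4ccc(C#N)cc4)n3)c(C)c2)cc1` gives 10000 nM
compound 3 `COc1cccc(-c2cc(C)c(Oc3cc(N)nc(Nc4ccc(C#N)cc4)n3)c(C)c2)c1` gives 19300 nM

These three share one core and differ only in the aryl group it carries. Compound 3 cannot be told apart from either of the others, as a 1.3-fold lower number from compound 1 to compound 3 (0.11 log units; within the scatter) and a 1.9-fold higher number from compound 2 to compound 3 (0.29 log units; within the scatter) both show. Only compounds 1 and 2 are separated, by a 2.5-fold lower number from compound 1 to compound 2 (0.40 log units; beyond the scatter) and that step is modest.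

The next compound is compound 4 `COc1ccc(-c2cc(C)c(Oc3cc(N)nc(Nc4ccc(C#N)cc4)n3)c(C)c2)cc1` which has the same atoms as compound 3, joined differently. The difference is 4-methoxyphenyl in place of 3-methoxyphenyl on an aromatic carbon so that 4-methoxyphenyl stands in place of 3-methoxyphenyl on the same aromatic carbon. This exact swap has not been measured. The closest evidence is the swaps among the three aryl groups above, and the largest of them is only modest. No step beyond the scatter is therefore expected in this assay here. The expectation leans slightly towards compound 2 with 10000 nM since its 4-methylphenyl is the nearest match to 4-methoxyphenyl among the measured groups.

The estimated change is a 1.3-fold lower number from compound 3 to compound 4 (0.11 log units; within the scatter) and no more than that is expected.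
For compound 4 the expected value is 15000 nM with an estimated range from 7000 nM to 30000 nM in this measurement.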

Compound 4, half-maximal cytotoxic concentration: 10700 nM
For compound 4 the middle estimate is 1.4-fold (0.15 log units) above the measured one; the range from low to high includes it.
By their numbers in this assay, from the lowest: compounds 2, 4, 3 and 1 (each within the scatter of the next, the first and the last beyond it).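

In this assay, shifting the methoxy group to another ring position while keeping the same atoms gives a 1.8-fold lower number from compound 3 to compound 4 (0.26 log units; within the scatter) and stays within the scatter, so this assay cannot tell 3-methoxyphenyl from 4-methoxyphenyl at this position. Methoxy in place of methyl gives a 1.1-fold higher number from compound 2 to compound 4 (0.03 log units; within the scatter) and also stays within the scatter, so 4-methoxyphenyl and 4-methylphenyl read alike here. The step from 2-chlorophenyl to 4-methoxyphenyl gives a 2.3-fold lower number from compound 1 to compound 4 (0.37 log units; beyond the scatter) and is modest, so compounds 2 and 4 are both set apart from compound 1. Compound 3 lies within the scatter of all three others, which goes against any simple split. No measurement shown accounts for these steps.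

The aryl groups shown carry only chloro, methyl or methoxy, so it remains open whether a phenyl ring bearing an amine or a carboxylic acid would fall in the same range in this assay. A longer chain such as butoxy in place of methoxy is also untested among these compounds, which leaves open how far this position tolerates larger groups before the numbers move well beyond the scatter.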